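A few compounds are considered here, and "the series" means these few. Any claim that something is new, unique, unknown or untested is made for them only; others in the source may bear on it.

For the measured compounds named here, in a functional assay on MGC-803 cells (Homo sapiens) for inhibition, read by MTT assay, with a stated time of 72 h (on this read-out higher numbers stand for weaker inhibition and lower numbers for stronger inhibition), compound 2 `Cc1cc(Nc2cc(-c3ccccc3)[nH]n2)n2nc(SCCCc3ccccc3)nc2n1` gives 6510 nM, the highest of the two numbers known here; the nearest, compound 1 `Cc1cc(Nc2cc(-c3ccccc3)[nH]n2)n2nc(SCc3ccccc3Br)nc2n1`, gives 3650 nM. Going by the values given here, the only measured step, a 1.8-fold higher number from compound 1 to compound 2 (0.25 log units; within the scatter), swapped one group on the chain for another. Compound 3 `CCCSc1nc2nc(C)cc(Nc3cc(-c4ccccc4)[nH]n3)n2n1` differs from compound 2 by hydrogen in place of phenyl on a saturated chain carbon, three bonds along the chain from a sulfur. Among the compounds with values here, no measured step matches this change, and the one step known stayed within the scatter, so for compound 3 a step no larger than the scatter is expected, a 1.2-fold higher number from compound 2 to compound 3 (0.09 log units; within the scatter). Compound 3 is therefore estimated at 8000 nM, with a range from 3000 nM to 22000 nM.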

Compound 3, half-maximal inhibitory concentration: 12600 nM
Estimate against measurement, compound 3: 1.6-fold (0.20 log units) below, within the range that was stated.
By their numbers in this assay, from the lowest: compounds 1, 2 and 3 (each within the scatter of the next, the first and the last beyond it).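

In this assay the phenyl on compound 2 can be replaced by hydrogen, leaving a plain propyl chain, with a 1.9-fold higher number from compound 2 to compound 3 (0.29 log units; within the scatter) as the result, so this single change stays too small to read. Ethyl in place of 2-bromophenyl on the saturated chain carbon bound to the sulfur gives a 3.5-fold higher number from compound 1 to compound 3 (0.54 log units; beyond the scatter) and is the first step here to pass the usual scatter. No supporting measurement explains either step.

On these data alone, whether an amine, a carboxylic acid or a longer chain on the sulfur would give lower numbers remains open.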